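A Second Chloro Substituent on the Shared Core

This account rests on a few compounds, and the source may have more. Where it says the series, first, only, none or still open, it means among the compounds named here.

Compound 2 `O=C(Nc1nc2ccc(Cl)cc2s1)c1cn(-c2ccccc2)nc1-c1ccccc1` gives 7670 nM in a functional assay on A549 cells (Homo sapiens) for cytotoxicity, read by MTT assay, with a stated time of 72 h (a higher number here means a weaker inhibitor, a lower number a stronger inhibitor), the lower of the two numbers recorded, although its distance from compound 1 lies within the scatter. Compound 1 `O=C(Nc1nc2ccccc2s1)c1cn(-c2ccccc2)nc1-c1ccccc1` gives 13500 nM in this assay, and the step of a 1.8-fold lower number from compound 1 to compound 2 (0.25 log units; within the scatter) is within the scatter. Compound 3 `O=C(Nc1nc2ccc(Cl)cc2s1)c1cn(-c2ccccc2)nc1-c1ccc(Cl)cc1` has not been measured; it differs from compound 2 by chloro in place of hydrogen on an aromatic carbon. Going by the values given here, the only step that bears on this, a 1.8-fold lower number from compound 1 to compound 2 (0.25 log units; within the scatter), was also a chloro in place of hydrogen and stayed within the scatter, so no step beyond the scatter is expected in this assay, at most a slight lowering. Compound 3 is therefore estimated at 6000 nM, between 2500 nM and 15000 nM. The expected step is a 1.3-fold lower number from compound 2 to compound 3 (0.11 log units; within the scatter).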

Compound 3, half-maximal inhibitory concentration: 4360 nM
Compound 3: middle estimate off by 1.4-fold (0.14 log units), on the high side, within the range that was stated.
By their numbers in this assay, from the lowest: compounds 3, 2 and 1 (each within the scatter of the next, the first and the last beyond it).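

In this assay the change from phenyl to 4-chlorophenyl gives a 1.8-fold lower number from compound 2 to compound 3 (0.25 log units; within the scatter) and so shows that this aromatic carbon, para to a large group, takes a chloro without a step beyond the scatter. Compound 1 and compound 2 carry the same phenyl here and could not show this. No measured evidence offers a reason for this result. The compounds shown leave open whether an amine or a carboxylic acid in place of this chloro would move the number beyond the scatter.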